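Aryl variation on the saturated ring carbon: working notes

This account rests on a few compounds, and the source may have more. Where it says the series, first, only, none or still open, it means among the compounds named here.

Measured so far in a functional assay on BGC-823 cells (Homo sapiens) for antiproliferative activity, read by MTT assay, tested at 5 uM; on this read-out higher numbers stand for a stronger effect at the one concentration tested and lower numbers for a weaker effect:
compound 1 `COc1cc(C2=NN(C(C)=O)C(c3c(Cl)cccc3Cl)O2)cc(OC)c1OC` — 15.9%
compound 2 `COc1cc(C2=NN(C(C)=O)C(c3cc(Cl)cc(Cl)c3)O2)cc(OC)c1OC` — 6.6%
compound 3 `COc1cc(C2=NN(C(C)=O)C(c3ccc(Cl)c(Cl)c3)O2)cc(OC)c1OC` — 3.1%

Compound 3 stands lowest of the three numbers in this assay. Its nearest neighbour is compound 2, and the step of a number 3.5 percentage points lower from compound 2 to compound 3 (within the scatter); the furthest is compound 1, and the step of a number 12.8 percentage points lower from compound 1 to compound 3 (beyond the scatter). The step of a number 9.3 percentage points lower from compound 1 to compound 2 (within the scatter) also lies within the scatter, so only the move from compound 1 to compound 3 separates cleanly.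

Compound 4 `COc1cc(C2=NN(C(C)=O)C(c3ccc(C(F)(F)F)cc3)O2)cc(OC)c1OC` is the next member. The change from compound 3 is 4-(trifluoromethyl)phenyl in place of 3,4-dichlorophenyl on a saturated ring carbon.

Among the measured compounds shown here, no measured step exchanges a dichlorophenyl for a trifluoromethyl-bearing phenyl, so the three steps bear only indirectly: two of them show that moving chlorine atoms around the ring stays within the scatter, and one shows a modest fall. For compound 4 the step of a number 3.9 percentage points higher from compound 3 to compound 4 (within the scatter) is therefore expected to remain within the scatter, with the number for compound 4 estimated at 7%, within 0% to 18%.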

Compound 4, a percentage reported as inhibition, at one concentration (the size of the read-out at that concentration, not a potency): 3.4%
Estimate against measurement, compound 4: 3.6 percentage points above; the measured number falls inside the stated range.
By their numbers in this assay, from the lowest: compounds 3, 4, 2 and 1 (each within the scatter of the next, the first and the last beyond it).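

In this assay the position takes 4-(trifluoromethyl)phenyl in place of a dichlorophenyl with no separable change: the reading is a number 0.3 percentage points higher from compound 3 to compound 4 (within the scatter) and likewise a number 3.2 percentage points lower from compound 2 to compound 4 (within the scatter). Against the 2,6-dichlorophenyl member the reading is a number 12.5 percentage points lower from compound 1 to compound 4 (beyond the scatter), so compound 1 stands clear of compound 3 and compound 4 but not of compound 2, and the gap to compound 1 is no longer tied to chlorine placement alone. Nothing available accounts for these numbers.

Still open, going by these compounds, is whether the higher number of compound 1 belongs to the 2,6-dichlorophenyl group itself or lies within ordinary spread. On these data alone, the response of this position to a phenyl bearing an amine or a carboxylic acid, or to a longer alkyl chain in place of the phenyl, also remains unknown.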